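The source may report more compounds than this note shows. Statements on the series, on what has been measured and on what is new or still open speak of the compounds shown alone.

Measured compounds, with their numbers in an assay on isolated protein for inhibition of DNA topoisomerase 1 (Homo sapiens), with a stated time of 15 min; a lower number here means a stronger inhibitor, a higher number a weaker inhibitor:
- compound 1 `O=C(O)c1cn(Cc2ccc(-n3cccn3)cc2)c2cc(N3C[C@H]4CCNC[C@H]4C3)c(F)cc2c1=O`: 31300 nM
- compound 2 `NC[C@@H]1CCN(c2cc3c(cc2F)c(=O)c(C(=O)O)cn3Cc2ccc(-n3cccn3)cc2)C1`: 91600 nM

Compound 2 has the highest of the two numbers; the only other point, compound 1, sits below it by a 2.9-fold higher number from compound 1 to compound 2 (0.47 log units; beyond the scatter), a step that is beyond the scatter but still modest. That step swaps the group on the core's aromatic carbon and leaves the benzyl side untouched.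

Compound 3 `NC[C@@H]1CCN(c2cc3c(cc2F)c(=O)c(C(=O)O)cn3Cc2ccc(-c3ccccc3)cc2)C1` keeps the core and the group of compound 2 and changes the benzyl side only: phenyl in place of 1H-pyrazol-1-yl on an aromatic carbon. Within the data shown here, no measured step touches this position, so the one step in hand, from compound 1 to compound 2, does not bear on it directly; it only shows that this series moves in modest steps. With nothing to point either way, the expectation for this assay is a step of no set direction and within the scatter, a 1.1-fold lower number from compound 2 to compound 3 (0.03 log units; within the scatter). Compound 3 is therefore estimated at 85000 nM, with a range from 28000 nM to 260000 nM; the high starting point of compound 2 makes a reported limit rather than a number a real possibility.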

Compound 3, half-maximal inhibitory concentration: 15600 nM
Beside the measured number, compound 3's estimate is 5.4-fold (0.74 log units) above it; the whole stated range lies above it.
By their numbers in this assay, from the lowest: compounds 3 and 1 (each within the scatter of the next); then compound 2.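

In this assay the benzyl side proves to be a place that moves the number, with phenyl in place of 1H-pyrazol-1-yl, para to a large group, giving a drop beyond the scatter (a 5.9-fold lower number from compound 2 to compound 3 (0.77 log units; beyond the scatter)). The earlier compounds shown here showed a change only in the group on the core's aromatic carbon (a 2.9-fold higher number from compound 1 to compound 2 (0.47 log units; beyond the scatter)), so two places now respond, each with a modest step beyond the scatter. The change swaps a five-membered aromatic ring with 2 hydrogen-bond acceptors for a six-membered aromatic ring of carbon only with 0 hydrogen-bond acceptors, and no measurement in hand explains why the number falls.

This single pair cannot separate ring size from the loss of the ring nitrogens, and a pyridyl ring at this place would bear on that question. Also open, going by these compounds, are whether phenyl in place of 1H-pyrazol-1-yl gives a step of like size on the group of compound 1, and how the number responds to a primary amine or a carboxylic acid on that ring.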